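The source may report more compounds than this note shows. Statements on the series, on what has been measured and on what is new or still open speak of the compounds shown alone.

Compound 1 `CN1CCC[C@@H]1Cn1nc(Cc2ccc(O)cc2)c2ccccc2c1=O` gives 251 nM in an assay for binding affinity to Alpha-1A adrenergic receptor (Homo sapiens); a higher number here means a weaker inhibitor, a lower number a stronger inhibitor. Among the three measured numbers it stands second highest. Compound 3 `CN1CCC[C@@H]1Cn1nc(Cc2ccc(F)c(F)c2)c2ccccc2c1=O` is nearest with 200 nM, the step being a 1.3-fold lower number from compound 1 to compound 3 (0.10 log units; within the scatter). Compound 2 `CN1CCC[C@@H]1Cn1nc(Cc2cccc(Cl)c2)c2ccccc2c1=O` is furthest with 398 nM, the step being a 1.6-fold higher number from compound 1 to compound 2 (0.20 log units; within the scatter). The remaining measured pair gives a 2.0-fold lower number from compound 2 to compound 3 (0.30 log units; within the scatter). None of the three steps reaches beyond the scatter, so the set so far is flat in this assay.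

Compound 4 `COc1ccc(Cc2nn(C[C@H]3CCCN3C)c(=O)c3ccccc23)cc1` differs from compound 1 in one place: methyl in place of hydrogen on an oxygen on an aromatic ring. Among the measured compounds shown here, no measured step touches this oxygen. The steps that do exist replace the whole 4-hydroxyphenyl with a 3-chlorophenyl or a 3,4-difluorophenyl, and each of them stays within the scatter. They bear on the present change only loosely, as they remove the hydroxy rather than alter it, yet they show that variation at this part of the molecule has shifted this assay little. The expectation for compound 4 is therefore a step of a 1.2-fold higher number from compound 1 to compound 4 (0.08 log units; within the scatter), none beyond the scatter. The estimate for compound 4 is 300 nM, with a range from 120 nM to 750 nM.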

Compound 4, inhibition constant: 126 nM
Estimate against measurement, compound 4: 2.4-fold (0.38 log units) above, and the stated range covers the measured number.
By their numbers in this assay, from the lowest: compounds 4, 3, 1 and 2 (each within the scatter of the next, the first and the last beyond it).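

In this assay, among the compounds shown here, the first measured change at the oxygen on the aromatic ring, methyl in place of hydrogen, gives a 2.0-fold lower number from compound 1 to compound 4 (0.30 log units; within the scatter) and so stays within the scatter, which means that the hydrogen of the hydroxy can be replaced by methyl with no resolved effect on this read-out. The 4-methoxyphenyl also cannot be separated from the 3,4-difluorophenyl, with a 1.6-fold lower number from compound 3 to compound 4 (0.20 log units; within the scatter) as the step, whereas a 3.2-fold lower number from compound 2 to compound 4 (0.50 log units; beyond the scatter) is a modest step and the only one in the set beyond the scatter, so variation at this part of the molecule is no longer entirely flat, although the only resolved gap is the one between the 3-chlorophenyl and the 4-methoxyphenyl. No supporting data bear on why this pair separates while the others do not.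

The compounds shown leave open how far the oxygen substituent can be extended, for example to an ethoxy group or to a longer chain ending in an amine. They also leave open what a carboxylic acid or an amine would do in place of the hydroxy on the phenyl ring.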